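The source may report more compounds than this note shows. Statements on the series, on what has been measured and on what is new or still open speak of the compounds shown alone.

Of the compounds shown here, two have numbers so far in a functional assay on CHO-K1 cells for antagonist activity at transient receptor potential cation channel subfamily V member 1 (Homo sapiens), read by FLIPR; on this read-out higher numbers stand for weaker inhibition and lower numbers for stronger inhibition. Compound 1 `CC(C(=O)NCc1ccc(C(F)(F)F)nc1N1CCCC1)c1ccc(NS(C)(=O)=O)c(F)c1` gives 211 nM in this assay. Compound 2 `CC(C(=O)NCc1ccc(C(F)(F)F)nc1N1CCC(Cc2ccc(F)c(F)c2)CC1)c1ccc(NS(C)(=O)=O)c(F)c1` gives 30 nM in this assay, the lowest of the two numbers, with compound 1 standing a clear distance above it, beyond the usual scatter of repeated measurements. Compound 3 `CC(=O)OC1CCN(c2nc(C(F)(F)F)ccc2CNC(=O)C(C)c2ccc(NS(C)(=O)=O)c(F)c2)CC1` has not yet been measured. It differs from compound 2 in one place: acetoxy in place of 3,4-difluorobenzyl on a saturated ring carbon. Within the data shown here, no pair of measured compounds differs by exactly this exchange, so nothing measured here shows directly how such a swap shifts the number. The swap does remove most of what sets compound 2 apart structurally from compound 1. Compound 3 is expected to move back upward, toward weaker inhibition, with an estimated step of a 5.0-fold higher number from compound 2 to compound 3 (0.70 log units; beyond the scatter). For compound 3 the estimate in this assay is 150 nM, with a range from 50 nM to 600 nM.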

Compound 3, half-maximal inhibitory concentration: 139 nM
Compound 3: middle estimate off by 1.1-fold (0.03 log units), on the high side, within the range that was stated.
By their numbers in this assay, from the lowest: compound 2; then compounds 3 and 1 (each within the scatter of the next).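

In this assay, acetoxy in place of 3,4-difluorobenzyl on this saturated ring carbon gives a 4.6-fold higher number from compound 2 to compound 3 (0.67 log units; beyond the scatter) and so shows that the choice of group at this carbon matters, since the lower number of compound 2 is lost with this swap. The larger ring carrying acetoxy shows no measurable gain over the shared core of compound 1, as 4-acetoxypiperidin-1-yl in place of pyrrolidin-1-yl gives a 1.5-fold lower number from compound 1 to compound 3 (0.18 log units; within the scatter) and leaves the two compounds indistinguishable. Nothing available here gives a reason for either step.

From the compounds shown here alone, whether a plain benzyl group, without its two fluorines, would keep the lower number of compound 2 stays open. So does whether a hydroxyl group or an amine on this carbon would behave like acetoxy.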